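This account rests on a few compounds, and the source may have more. Where it says the series, first, only, none or still open, it means among the compounds named here.

Within the data shown here, in a functional assay (strain AB) with Danio rerio as the target, read by microscopy, with a stated time of 1 h (on this read-out lower numbers stand for an effect already at smaller amounts and higher numbers for an effect only at larger amounts of compound), compound 3 `CCN1CCc2c(sc(NC(=O)Nc3ccc(Br)cc3)c2C(N)=O)C1` gives 3130 nM as the only true number among the three compounds measured. Compound 1 `CCN1CCc2c(sc(NC(=O)Nc3ccccc3)c2C(N)=O)C1` shows only the limit > 25000 nM and no number. Compound 2 `CCN1CCc2c(sc(NC(=O)CN3CCCCC3)c2C(N)=O)C1` also shows only the limit > 25000 nM and no number. Compound 4 `CCN1CCc2c(sc(NC(=O)c3ccccc3)c2C(N)=O)C1` differs from compound 3 at one place, with phenyl in place of (4-bromophenyl)amino on a carbonyl carbon. Like compound 1, compound 4 carries no bromo. Bromo in place of hydrogen on an aromatic carbon gave an at least 7.9-fold lower number from compound 1 to compound 3 (0.90 log units; beyond the scatter) and is the closest guide, while a change on the same carbonyl carbon gave an at least 7.9-fold lower number from compound 2 to compound 3 (0.90 log units; beyond the scatter) as well. Without the bromo a higher number is expected, the expected move being a 3.5-fold higher number from compound 3 to compound 4 (0.55 log units; beyond the scatter) with a real chance that only the limit appears. Compound 4 is estimated at 11000 nM with an expected range of 3500 nM to 25000 nM around it.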

Compound 4, half-maximal effective concentration: > 25000 nM
Compound 4 was reported as a limit (the forecaster's own chance of this, stated with the estimate: 45%); at least 2.2-fold (0.35 log units) between middle value and limit.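

Replacing (4-bromophenyl)amino with phenyl on the carbonyl carbon gives an at least 7.9-fold higher number from compound 3 to compound 4 (0.90 log units; beyond the scatter) in this assay; the value of compound 4 is a limit. This is the first step to remove the bromo and the linking nitrogen together, and among these four compounds only the bromo-bearing compound 3 gives a true number. The steps to compound 4 from compound 1 and compound 2 cannot be read, since all three sit at one limit: the limit of > 25000 nM in this assay, at which 3 of the 4 values shown sit.

Still open, on these data alone, is whether 4-bromophenyl on that carbonyl carbon, without the nitrogen, would give a true number. As far as these compounds go, whether chloro could stand in for bromo is also open.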